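Hydroxy in Place of Fluoro: What Compound 3 Might Give

The source may hold more compounds than are shown below. What is called first, only, known or untested is meant among the compounds shown, and "the series" means these compounds.

Compound 1 `COc1ccc2[nH]c(C(=O)Cc3cccnc3)cc2c1`: 49000 nM
Compound 2 `O=C(Cc1cccnc1)c1cc2cc(F)ccc2[nH]1`: 36000 nM

Of the compounds shown here, two have been measured in an assay on isolated protein for inhibition of Indoleamine 2,3-dioxygenase 1 (Homo sapiens), read by spectrophotometry; a higher number here means a weaker inhibitor, a lower number a stronger inhibitor. Compound 1 gives 49000 nM, and compound 2 gives 36000 nM. Within the data shown here, the one step between them, a 1.4-fold lower number from compound 1 to compound 2 (0.13 log units; within the scatter), lies within the scatter, so compound 2 and compound 1 cannot be told apart on these numbers; compound 2 is simply the other of the two measured points.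

Compound 3 `O=C(Cc1cccnc1)c1cc2cc(O)ccc2[nH]1` is the next compound. It differs from compound 2 by hydroxy in place of fluoro on an aromatic carbon. Among the measured compounds shown here, the only measured step that bears on this position is the exchange from compound 1 to compound 2, which was a 1.4-fold lower number from compound 1 to compound 2 (0.13 log units; within the scatter), that is, within the scatter. For the measured compounds named here, no measured compound carries a hydroxy group at this site, so the information is thin. Going by the values given here, on the one available step, a change at this carbon is not expected to move the number beyond the scatter.

The value for compound 3 in this assay is therefore expected to be 36000 nM, with a range from 12000 nM to 110000 nM. The expected step from compound 2 to compound 3 is no change at the digits printed from compound 2 to compound 3 (within the scatter).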

Compound 3, half-maximal inhibitory concentration: 37000 nM
Estimate against measurement, compound 3: 1.0-fold (0.01 log units) below; the range from low to high includes it.
By their numbers in this assay, from the lowest: compounds 2, 3 and 1 (each within the scatter of the next).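

With a hydrogen-bond donor and acceptor now counted at this carbon where fluoro has none, the exchange of fluoro for hydroxy gives a 1.0-fold higher number from compound 2 to compound 3 (0.01 log units; within the scatter) in this assay, so this difference in the counts does not separate the two compounds on these numbers. Taking the methyl off the oxygen gives a 1.3-fold lower number from compound 1 to compound 3 (0.12 log units; within the scatter) and is likewise no readable difference, which means that methoxy, fluoro and hydroxy on this aromatic carbon of the shared core cannot be told apart from one another in this assay. Nothing on hand explains why these three groups read alike.

This agreement covers only these three single-atom-linked or single-atom groups, and it does not show whether the carbon would tolerate anything else, such as a plain hydrogen, an amine, a carboxylic acid or a longer chain. All three compounds also share the rest of the structure, so they leave open whether a change to the carbonyl link or to the other ring would give a step beyond the scatter in this assay at all.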